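From 4-fluorophenyl to 3-chlorophenyl: compound 3 awaits measurement

The source may hold more compounds than are shown below. What is called first, only, known or untested is meant among the compounds shown, and "the series" means these compounds.

Compound 1 `S=C(N/N=C/c1ccc2ccccc2n1)Nc1ccccc1Br`: > 100000 nM (a limit of the assay)
Compound 2 `Fc1ccc(NC(=S)N/N=C/c2ccc3ccccc3n2)cc1`: 33200 nM

Among the measured compounds shown here, in a functional assay on HeLa cells (Homo sapiens) for antiproliferative activity, read by sulforhodamine B assay, with a stated time of 72 h (on this read-out lower numbers stand for stronger inhibition and higher numbers for weaker inhibition), compound 2 gives 33200 nM, the only actual number so far. Compound 1 offers only a limit, as the limit of > 100000 nM in this assay, at which 1 of the 2 values shown sits, records. The next compound is compound 3 `S=C(N/N=C/c1ccc2ccccc2n1)Nc1cccc(Cl)c1`, and the change is 3-chlorophenyl in place of 4-fluorophenyl on an amide-type nitrogen. For the measured compounds named here, one measured step bears on this place, an at least 3.0-fold lower number from compound 1 to compound 2 (0.47 log units; beyond the scatter), which lies beyond the scatter. As far as these compounds go, its true size stays open, since it starts from a limit, and it involves a different pair of groups. It shows that a change here can move the number in this assay, but it gives no direction for the new group. The estimated change is a 1.1-fold lower number from compound 2 to compound 3 (0.04 log units; within the scatter), so no shift beyond the scatter is expected, though the uncertainty is wide. For compound 3 the expected value is 30000 nM, with an estimated range from 9000 nM to 100000 nM.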

Compound 3, half-maximal inhibitory concentration: 52500 nM
The estimate for compound 3 lay 1.8-fold (0.24 log units) below the measured number; the measured number falls inside the stated range.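

In this assay, the change on the amide-type nitrogen gives a 1.6-fold higher number from compound 2 to compound 3 (0.20 log units; within the scatter), so 3-chlorophenyl and 4-fluorophenyl cannot be told apart on this read-out. Among the compounds shown here, this is the first comparison at this place between two actual numbers, as the earlier step started from a limit. The comparison with 2-bromophenyl reads an at least 1.9-fold lower number from compound 1 to compound 3 (0.27 log units; that floor lies within the scatter), and its true size stays open, as the value of compound 1 is a limit of the assay: the limit of > 100000 nM in this assay, at which 1 of the 3 values shown sits.

The three compounds differ in both the halogen and its place on the phenyl ring, so the effects of these two features cannot be separated. As far as these compounds go, whether an amine, a carboxylic acid or a methoxy group on the phenyl ring, or a cyclohexyl group in place of that ring, would move the number also stays open.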